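Working notes: rearranging the group on the carbonyl carbon

This account rests on a few compounds, and the source may have more. Where it says the series, first, only, none or still open, it means among the compounds named here.

- Compound 1 `CO[C@H]1CC[C@H](NC(=O)c2n[nH]cc2NC(=O)c2c(C)nc3ccccn23)CC1`: 34000 nM
- Compound 2 `CO[C@H]1CC[C@H](NC(=O)c2n[nH]cc2NC(=O)c2cnc3ccccn23)CC1`: 5900 nM

In an ADME assay on MRC5 cells (Homo sapiens) for inhibition, with a stated time of 72 h (a lower number here means that less compound is needed, a higher number that more compound is needed for the effect), compound 2 gives 5900 nM, the lower of the two numbers available, while compound 1 gives 34000 nM. Compound 3 `CO[C@H]1CC[C@H](NC(=O)c2n[nH]cc2NC(=O)c2cc3ccccn3n2)CC1` has not been measured. The structural change is a group of 9 heavy atoms (7 carbon, 2 nitrogen; one five-membered aromatic ring with 2 hetero atoms, one six-membered aromatic ring with 1 hetero atom) in place of a group of 9 heavy atoms (7 carbon, 2 nitrogen; one five-membered aromatic ring with 2 hetero atoms, one six-membered aromatic ring with 1 hetero atom), on a carbonyl carbon. The two compounds have the same atoms, joined differently, so the change lies in the arrangement of the group and not in its composition.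

Among the measured compounds shown here, only one measured step is available, a 5.8-fold lower number from compound 1 to compound 2 (0.76 log units; beyond the scatter), which is beyond the scatter and modest in size. It comes from hydrogen in place of methyl on an aromatic carbon, a different kind of change, so it bears only loosely on this one. It does show that this assay can respond to a single small edit in this series. The data give no direct guide to direction. A modest move towards a higher number is expected, no larger than that measured step. The expected change is a 1.9-fold higher number from compound 2 to compound 3 (0.27 log units; within the scatter). For compound 3 the estimated value is 11000 nM, with an expected range from 3500 nM to 35000 nM.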

Compound 3, half-maximal effective concentration: 1000 nM
For compound 3 the middle estimate is 11-fold (1.04 log units) above the measured one; measured number below the stated range.
By their numbers in this assay, from the lowest: compound 3; then compound 2; then compound 1.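

In this assay, the rearrangement of the group on the carbonyl carbon gives a 5.9-fold lower number from compound 2 to compound 3 (0.77 log units; beyond the scatter) and so moves the number beyond the scatter, although the group keeps the same atoms and the same counts of hydrogen-bond donors and acceptors. The earlier pair showed a response only to a change in composition, hydrogen in place of methyl on an aromatic carbon, with a 5.8-fold lower number from compound 1 to compound 2 (0.76 log units; beyond the scatter) as its step; this pair shows that the way the group is joined can matter on its own. Nothing available bears on why the two arrangements differ in this way.

The compounds shown leave open whether the arrangement in compound 3 would respond to methyl on an aromatic carbon as the arrangement in compound 2 does, since the two edits are not combined in any compound here. They also leave open how far this position tolerates a different kind of group on the carbonyl carbon, such as a simple phenyl ring or a carboxylic acid, in place of the two-ring groups seen so far.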